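Imidazole for Piperazine on the Outer Ring of a Urea

The compounds below may be only part of what the source reports. "The series", "measured", "known", "first", "only" and "open" are said of these compounds alone.

Compound 1 `Cc1cc(C)c(NC(=O)N(Cc2ccc(N3CCN(C)CC3)cc2)C2CCCCCC2)c(C)c1` carries a 4-methylpiperazin-1-yl group on a six-membered aromatic ring of carbon only, attached to the shared core. In a functional assay on a cell-free system (plasma) with sterol O-acyltransferase, Soat (Rattus norvegicus) as the target (on this read-out lower numbers stand for an effect already at smaller amounts and higher numbers for an effect only at larger amounts of compound), compound 1 gives only a limit, > 1 mg/kg, so its place among the numbers shown is open (the limit of > 1 mg/kg in this assay, at which 1 of the 3 values shown sits). Two related compounds frame the question. Compound 2 `Cc1cc(C)c(NC(=O)N(Cc2cccc(-c3cn[nH]c3)c2)C2CCCCCC2)c(C)c1` gives 0.19 mg/kg in this assay, a measured number. Compound 3 `Cc1cc(C)c(NC(=O)N(Cc2cccc(-c3ccn(C)n3)c2)C2CCCCCC2)c(C)c1` gives only a limit in this assay, < 1 mg/kg (the limit of < 1 mg/kg in this assay, at which 1 of the 3 values shown sits). The step that the limit leaves unreadable from compound 2 to compound 3 therefore has no readable size.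

Compound 4 `Cc1cc(C)c(NC(=O)N(Cc2ccc(-n3ccnc3)cc2)C2CCCCCC2)c(C)c1` has not yet been measured. It differs from compound 1 by 1H-imidazol-1-yl in place of 4-methylpiperazin-1-yl on an aromatic carbon. For the measured compounds named here, no measured step makes this same change; the one step available, from compound 2 to compound 3, exchanges one five-membered aromatic ring for another and stays unreadable. Still, compound 2 shows that a five-membered aromatic ring with two hetero atoms on the outer ring can reach 0.19 mg/kg. Compound 4 is therefore expected near 0.5 mg/kg, within 0.15 mg/kg to 2 mg/kg. The expected step of an at least 2.0-fold lower number from compound 1 to compound 4 (0.30 log units; that floor lies within the scatter) would move compound 4 toward smaller doses, though the limit on compound 1 makes its size uncertain.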

Compound 4, dose for half-maximal effect: > 1 mg/kg
Compound 4: only a limit was reported; the forecaster's own chance of this, stated with the estimate: 40%; middle value at least 2.0-fold (0.30 log units) from the limit.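

Compound 1 gives only a limit in this assay, > 1 mg/kg. Compound 4 also gives only a limit, > 1 mg/kg, so no step can be read between compound 1 and compound 4. The compounds shown leave open where these two truly lie, and whether 1H-imidazol-1-yl in place of 4-methylpiperazin-1-yl shifts the dose at all.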